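Trimethoxyphenyl Hydrazone in a Glioblastoma Cytotoxicity Series

The compounds below may be only part of what the source reports. "The series", "measured", "known", "first", "only" and "open" are said of these compounds alone.

Among the compounds with values here, compound 2 `CN(C)CCn1cnnc1-c1cc(Oc2ccc(NC(=O)N/N=C/c3ccc(O)c(Br)c3)cc2F)ccn1` gives 12400 nM in a functional assay on U-87MG ATCC cells (Homo sapiens) for cytotoxicity, read by MTT assay, with a stated time of 72 h (a higher number here means a weaker inhibitor, a lower number a stronger inhibitor), the higher of the two numbers measured so far; its nearest neighbour, compound 1 `CN(C)CCn1cnnc1-c1cc(Oc2ccc(NC(=O)N/N=C/c3ccc(Cl)cc3Cl)cc2F)ccn1`, gives 2330 nM in this assay. Within the data shown here, the only recorded step, a 5.3-fold higher number from compound 1 to compound 2 (0.73 log units; beyond the scatter), changes the same aryl group on a carbon with a double bond to nitrogen that is altered in the step now considered. Compound 3 `COc1ccc(/C=N/NC(=O)Nc2ccc(Oc3ccnc(-c4nncn4CCN(C)C)c3)c(F)c2)c(OC)c1OC` differs from compound 2 by 2,3,4-trimethoxyphenyl in place of 3-bromo-4-hydroxyphenyl on a carbon with a double bond to nitrogen. Among the measured compounds shown here, no measured step introduces methoxy groups, so the bearing of the step from compound 1 to compound 2 is indirect: it shows only that this aryl group can shift the number by a modest amount in this assay. Compound 3 is therefore expected to stay near compound 2, with the step of a 1.6-fold lower number from compound 2 to compound 3 (0.19 log units; within the scatter) estimated to lie close to the scatter and without a firm direction. The estimate for compound 3 is 8000 nM, within 2500 nM to 25000 nM.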

Compound 3, half-maximal inhibitory concentration: 7650 nM
Beside the measured number, compound 3's estimate is 1.0-fold (0.02 log units) above it; the range from low to high includes it.
By their numbers in this assay, from the lowest: compound 1; then compounds 3 and 2 (each within the scatter of the next).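

In this assay, the exchange on the carbon with a double bond to nitrogen gives a 1.6-fold lower number from compound 2 to compound 3 (0.21 log units; within the scatter), so 3-bromo-4-hydroxyphenyl and 2,3,4-trimethoxyphenyl, with 8 and 12 heavy atoms, are not told apart here despite sharing no substituent. The second new step, a 3.3-fold higher number from compound 1 to compound 3 (0.52 log units; beyond the scatter), agrees with the earlier 5.3-fold higher number from compound 1 to compound 2 (0.73 log units; beyond the scatter) in setting compound 1, with its 2,4-dichlorophenyl group, apart as the strongest inhibitor of the three. No measurement offered here accounts for either step.

The compounds shown leave open whether the separation of compound 1 depends on having both chlorine atoms or on their placing on the ring. They also do not show whether an aryl group carrying a single chlorine, an amine or a carboxylic acid would fall with compound 1 or with compound 2 and compound 3.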